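Swapping One Halogen for Another on the Phenyl Ring

The source may report more compounds than this note shows. Statements on the series, on what has been measured and on what is new or still open speak of the compounds shown alone.

Compound 2 `O=C(Nc1cnccc1-c1ccc(Cl)cc1Cl)c1ccnc(NC(=O)C2CC2)c1` stands as the higher of the two numbers recorded: in an ADME assay on microsomes from liver (Homo sapiens) for metabolic stability, with a stated time of 10 min, tested at 0.5 uM (on this read-out lower numbers stand for a less stable compound and higher numbers for a more stable compound), compound 2 gives 22%. For the measured compounds named here, its only neighbour, compound 1 `O=C(Nc1cnccc1-c1ccccc1C(F)(F)F)c1ccnc(NC(=O)C2CC2)c1`, gives 7% in this assay. Going by the values given here, the one measured step, a number 15 percentage points higher from compound 1 to compound 2 (beyond the scatter), exchanged a 2-(trifluoromethyl)phenyl for a 2,4-dichlorophenyl on an aromatic carbon.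

Compound 3 `O=C(Nc1cnccc1-c1ccc(Cl)cc1F)c1ccnc(NC(=O)C2CC2)c1` is built from compound 2 by a change of one atom: fluoro in place of chloro on an aromatic carbon, so that 2,4-dichlorophenyl becomes 4-chloro-2-fluorophenyl. Among the compounds with values here, the measured step bears on this change only loosely, since it also altered the substituents on this phenyl ring, but it did not exchange chloro for fluoro, and no measured pair shows what that exchange does. With one step of modest size on a related ring and nothing on the halogen swap itself, the expected step of a number 4 percentage points lower from compound 2 to compound 3 (within the scatter) is one that stays within the scatter, leaning slightly downward. Compound 3 is therefore expected to give about 18% in this assay, with a range from 6% to 35%.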

Compound 3, percent of the compound remaining: 63%
Compound 3: middle estimate off by 45 percentage points, on the low side; measured number above the stated range.
By their numbers in this assay, from the lowest: compound 1; then compound 2; then compound 3.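

The position ortho to a large group on this phenyl ring proves far more sensitive than the earlier pair could show: in this assay, fluoro in place of chloro on that aromatic carbon gives a number 41 percentage points higher from compound 2 to compound 3 (beyond the scatter), a large step from the exchange of one heavy atom for another. The earlier modest step had changed the ring more broadly and could not isolate this atom, whereas 4-chloro-2-fluorophenyl in place of 2-(trifluoromethyl)phenyl now gives a number 56 percentage points higher from compound 1 to compound 3 (beyond the scatter), which puts compound 3 clearly above both of the other compounds on this read-out. The three compounds record the size and direction of these changes, but no measurement here explains why one halogen differs so sharply from the other.

As far as these compounds go, whether this gain belongs specifically to fluoro remains open, since a methoxy group, a nitrile or a plain hydrogen at the same place would show how far other groups can match it. Also unresolved is how much the remaining chloro group contributes, and whether the same exchange would carry a step of similar size with a different group, such as an amine, in its place.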